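Side-chain amine change from compound 2 to compound 3

The source may hold more compounds than are shown below. What is called first, only, known or untested is meant among the compounds shown, and "the series" means these compounds.

Measured in a functional assay on HT-29 cells (Homo sapiens) for cytotoxicity, read by MTT assay, with a stated time of 72 h; a higher number here means a weaker inhibitor, a lower number a stronger inhibitor: compound 1 `CN(C)CCCNc1nc(-c2ccc(NC(=O)Nc3ccc(Cl)cc3)cc2)nc2c(Cl)c(Cl)sc12` gives 330 nM; compound 2 `Cc1ccc(NC(=O)Nc2ccc(-c3nc(NCCCN(C)C)c4sc(Cl)c(Cl)c4n3)cc2)cc1` gives 1320 nM.

Compound 2 holds the higher of the two numbers in this assay. Among the compounds with values here, the only measured step, a 4.0-fold higher number from compound 1 to compound 2 (0.60 log units; beyond the scatter), concerns the urea end and is modest. Compound 3 `CCN(CC)CCNc1nc(-c2ccc(NC(=O)Nc3ccc(C)cc3)cc2)nc2c(Cl)c(Cl)sc12` differs from compound 2 by diethylamino in place of (dimethylamino)methyl on a saturated chain carbon, two bonds along the chain from a nitrogen on an aromatic ring. Within the data shown here, no measured step touches this chain, so nothing beyond the scatter is expected; the expected step is a 1.0-fold lower number from compound 2 to compound 3 (0.01 log units; within the scatter). Compound 3 is estimated at 1300 nM, within 500 nM to 3500 nM.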

Compound 3, half-maximal inhibitory concentration: 950 nM
Compound 3: middle estimate off by 1.4-fold (0.14 log units), on the high side; measured number inside the range.
By their numbers in this assay, from the lowest: compound 1; then compounds 3 and 2 (each within the scatter of the next).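

In this assay, diethylamino in place of (dimethylamino)methyl gives a 1.4-fold lower number from compound 2 to compound 3 (0.14 log units; within the scatter), so this chain carbon accepts the change without a step beyond the scatter. Unlike the methyl in place of chloro step, a 4.0-fold higher number from compound 1 to compound 2 (0.60 log units; beyond the scatter), this change, read as 3-(dimethylamino)propyl to 2-(diethylamino)ethyl, leaves the two numbers indistinguishable. No measurement on hand bears on this result.

Chain length and the substituents on the amine change together here, so their separate contributions stay unresolved. Also open, as far as these compounds go, is how a morpholine or a piperidine at the chain end, or a longer chain, would read.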